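Oxime ethers of the shared core: a chloro-to-methoxy exchange

A few compounds are considered here, and "the series" means these few. Any claim that something is new, unique, unknown or untested is made for them only; others in the source may bear on it.

The series is followed in an assay on HepG2 cells for agonist activity at nuclear receptor subfamily 1 group I member 3 (Homo sapiens), read by a luciferase reporter, with a stated time of 23 h; a lower number here means that less compound is needed, a higher number that more compound is needed for the effect. Of the compounds shown here, two carry numbers so far. Compound 1 `Clc1cccc(-c2nc3sccn3c2/C=N/OCc2ccc(Cl)c(Cl)c2)c1` gives 1100 nM in this assay, the highest of the two numbers. Going by the values given here, compound 2 `FC(F)(F)c1ccc(CO/N=C/c2c(-c3ccc4ccccc4c3)nc3occn23)cc1` gives 470 nM in this assay, a lower number than compound 1 and beyond the usual scatter; the two differ in more than one place, so no single step is read between them.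

The next compound, compound 3 `COc1ccc(-c2nc3sccn3c2/C=N/OCc2ccc(Cl)c(Cl)c2)cc1`, keeps the oxime ether and the core of compound 1 and changes only the aryl group: 4-methoxyphenyl in place of 3-chlorophenyl on an aromatic carbon, on an aromatic carbon of a five-membered aromatic ring with 2 nitrogen, part of a fused or bridged system of two rings. Among the compounds with values here, no measured pair shows this exchange in this assay, so there is no step to lean on.

The step from compound 1 to compound 3 is expected to be small, a 1.2-fold lower number from compound 1 to compound 3 (0.09 log units; within the scatter), with no preferred direction beyond the scatter. For compound 3 the expected value in this assay is 900 nM, within a range of 300 nM to 2700 nM.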

Compound 3, half-maximal effective concentration: 490 nM
Compound 3: middle estimate off by 1.8-fold (0.26 log units), on the high side; low and high end bracket the measured number.
By their numbers in this assay, from the lowest: compounds 2 and 3 (each within the scatter of the next); then compound 1.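

Within this assay, 4-methoxyphenyl in place of 3-chlorophenyl on an aromatic carbon gives a 2.2-fold lower number from compound 1 to compound 3 (0.35 log units; beyond the scatter) and is the first single-place step in the series, a modest one. With the oxime ether and the shared core held constant, this shows that the aryl group at this place, next to the ring nitrogen, can shift the number beyond the scatter, something compound 1 and compound 2 could not show, as they differ in more than one place. No measured finding at hand accounts for the direction or size of this step.

The exchange alters both the substituent and its place on the phenyl ring, so the compounds shown leave open whether the step follows from methoxy replacing chloro, from the shift from the 3-substituted to the 4-substituted ring, or from both together. A 4-chlorophenyl or 3-methoxyphenyl group would separate these two changes, while an unsubstituted phenyl or a 4-aminophenyl group would show how far the step extends beyond these two aryl groups.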